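Replacing an aryl sulfonyl group with an aminoethyl chain

The source may hold more compounds than are shown below. What is called first, only, known or untested is meant among the compounds shown, and "the series" means these compounds.

Measured compounds:
- compound 1, `Cc1ccccc1S(=O)(=O)NC(=O)c1ccc(Nc2nc(NC3(c4ccc(Cl)cc4)CC3)nc(OCC(F)(F)F)n2)cc1`: 100%
- compound 2, `CC(C)(C)NC(=O)NCCS(=O)(=O)NC(=O)c1ccc(Nc2nc(NC3(c4ccc(Cl)cc4)CC3)nc(OCC(F)(F)F)n2)cc1`: 93%
- compound 3, `CC(C)(C)OC(=O)NCCS(=O)(=O)NC(=O)c1ccc(Nc2nc(NC3(c4ccc(Cl)cc4)CC3)nc(OCC(F)(F)F)n2)cc1`: 93%

In an ADME assay on microsomes from liver (Rattus norvegicus) for metabolic stability, with a stated time of 10 min (a higher number here means that more of the compound is left, a lower number that less of the compound is left), compound 1 gives 100%, the highest of the three numbers, though its distance to each of the others lies within the scatter. Compound 4, `NCCS(=O)(=O)NC(=O)c1ccc(Nc2nc(NC3(c4ccc(Cl)cc4)CC3)nc(OCC(F)(F)F)n2)cc1`, has not yet been measured. It differs from compound 1 in one place: 2-aminoethyl in place of 2-methylphenyl on a sulfonyl sulfur. Two measured steps resemble this change, each swapping the same 2-methylphenyl for a two-carbon chain carrying a nitrogen: a number 7 percentage points lower from compound 1 to compound 2 (within the scatter) and a number 7 percentage points lower from compound 1 to compound 3 (within the scatter). Both stayed within the scatter, and the swap between their end groups, no change at the digits printed from compound 2 to compound 3 (within the scatter), changed nothing. A step of similar size is therefore expected, a number 10 percentage points lower from compound 1 to compound 4 (within the scatter). The expected value for compound 4 is 90%, between 70% and 100%.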

Compound 4, percent of the compound remaining: 100%
Estimate against measurement, compound 4: 10 percentage points below; the measured number falls inside the stated range.
By their numbers in this assay, from the lowest: compounds 2, 3, 1 and 4 (each within the scatter of the next).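

Placing 2-aminoethyl on the sulfonyl sulfur gives no change at the digits printed from compound 1 to compound 4 (within the scatter) in this assay, so here a short chain ending in a free amine does as well as the aromatic ring. Taking the caps off the amine nitrogen gives a number 7 percentage points higher from compound 3 to compound 4 (within the scatter) and a number 7 percentage points higher from compound 2 to compound 4 (within the scatter), so neither tert-butoxycarbonyl nor (tert-butyl)carbamoyl is needed to keep this number. No available evidence accounts for these results. Going by these compounds, all four numbers lie within the scatter of one another, so it remains open which group at this position would lower the number, for instance a longer chain or a carboxylic acid.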